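A few compounds are considered here, and "the series" means these few. Any claim that something is new, unique, unknown or untested is made for them only; others in the source may bear on it.

Compound 1 `O=C(CCCSC[C@H](NC(=O)OCc1ccccc1)C(=O)Nc1ccccc1)NO` is the reference point for the series. In an assay on Sf9 cells for inhibition of histone deacetylase 7 (Homo sapiens), read by fluorescence, with a stated time of 1 h (a higher number here means a weaker inhibitor, a lower number a stronger inhibitor), compound 1 gives > 200 nM, which is a limit of the assay and not a measured number. Among the measured compounds shown here, its one measured neighbour is compound 2 `O=C(CCCSC[C@H](NC(=O)OCc1ccccc1)C(=O)Nc1cccc2ccccc12)NO`, in which a naphthalen-1-yl replaces the phenyl on the amide-type nitrogen. In this assay compound 2 gives > 200 nM, again a limit and not a number. The step that the two limits leave unreadable from compound 1 to compound 2 therefore cannot be read for size or direction; the limit of > 200 nM in this assay, at which 2 of the 2 values shown sit, is all the evidence the measured pair offers.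

Compound 3 `O=C(CCCSC[C@H](NC(=O)c1ccccc1)C(=O)Nc1ccccc1)NO` differs from compound 1 at a different place: phenyl in place of benzyloxy on a carbonyl carbon. For the measured compounds named here, no measured step touches this carbonyl carbon, and the change has no precedent to weigh it against. The step that the limit leaves unreadable from compound 1 to compound 3 is expected to be modest, with no movement beyond the scatter assumed in either direction. Compound 3 is therefore expected to give 500 nM in this assay, with a range from 200 nM to 5000 nM, and it may well return only a limit once more.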

Compound 3, half-maximal inhibitory concentration: > 200 nM
Compound 3 gave a limit, no number; the forecaster's own chance of this, stated with the estimate: 70%; the middle value does not contradict the limit.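

In this assay compound 3 gives > 200 nM, a limit and not a number. Compound 1 also gives only a limit, so no step can be read between compound 1 and compound 3. The compounds shown leave open how strongly any of them inhibits and whether either change moves the value, with a single reading throughout: the limit of > 200 nM in this assay, at which 3 of the 3 values shown sit.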